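Methyl on the benzyl ring: cytotoxicity of compound 3 in HepG2 cells

This account rests on a few compounds, and the source may have more. Where it says the series, first, only, none or still open, it means among the compounds named here.

Measured compounds:
- compound 1, `Fc1ccc(-c2n[nH]cc2/C=N/n2c(OCc3ccccc3)n[nH]c2=S)cc1`: 71 ug/mL
- compound 2, `S=c1[nH]nc(OCc2ccccc2)n1/N=C/c1c[nH]nc1-c1ccc(Cl)cc1`: 18 ug/mL

Of the two measured compounds, compound 1 stands at the higher number in a functional assay on HepG2 cells (Homo sapiens) for cytotoxicity, read by MTT assay, with a stated time of 24 h; on this read-out higher numbers stand for weaker inhibition and lower numbers for stronger inhibition; its nearest neighbour is compound 2, and the step of a 3.9-fold lower number from compound 1 to compound 2 (0.60 log units; beyond the scatter) is the only one recorded. Compound 3, `Cc1ccccc1COc1n[nH]c(=S)n1/N=C/c1c[nH]nc1-c1ccc(F)cc1`, differs from compound 1 in one place: methyl in place of hydrogen on an aromatic carbon, on an aromatic carbon of a six-membered aromatic ring of carbon only, ortho to a large group. Among the measured compounds shown here, the one measured step, from compound 1 to compound 2, concerns a halogen exchange on the other aromatic ring, not the benzyloxy part, so it does not bear directly on this change. For the measured compounds named here, there is no measured methyl-for-hydrogen step at all. Compound 3 is therefore expected to stay close to compound 1, with the step of a 1.2-fold lower number from compound 1 to compound 3 (0.07 log units; within the scatter) expected to lie within the scatter. The estimate for compound 3 in this assay is 60 ug/mL, with a range from 25 ug/mL to 150 ug/mL.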

Compound 3, half-maximal inhibitory concentration: 48 ug/mL
Compound 3: the middle estimate sits 1.3-fold (0.10 log units) above what was measured, within the range that was stated.
By their numbers in this assay, from the lowest: compound 2; then compounds 3 and 1 (each within the scatter of the next).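

In this assay, the benzyl ring now has its first measured change: methyl in place of hydrogen, on an aromatic carbon ortho to a large group, gives a 1.5-fold lower number from compound 1 to compound 3 (0.17 log units; within the scatter) and so stays within the scatter. The earlier step concerned only the halogen on the other aromatic ring, whereas this one shows that going from benzyl to 2-methylbenzyl, at this one place, does not move the number beyond the scatter. No measured information on these compounds accounts for this result.

The compounds shown leave open whether an amine, a methoxy group or a carboxylic acid at this same place would shift the number beyond the scatter. They also leave open whether the methyl would behave in the same way with chloro in place of fluoro on the other aromatic ring.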